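A few compounds are considered here, and "the series" means these few. Any claim that something is new, unique, unknown or untested is made for them only; others in the source may bear on it.

Measured so far:
Compound 1 `Cc1ccc(-c2cc(/C=C/c3ccc(C(=O)NO)cc3)ccn2)cc1`: in a functional assay on MGC-803 cells (Homo sapiens) for antiproliferative activity, read by CellTiter-Glo, with a stated time of 72 h (on this read-out lower numbers stand for stronger inhibition and higher numbers for weaker inhibition), compound 1 gives 1910 nM.
Compound 2 `O=C(NO)c1ccc(/C=C/c2ccnc(-c3ccc(C(F)(F)F)cc3)c2)cc1`: in this assay compound 2 reaches only a limit of the assay, > 10000 nM.
Compound 3 `Cc1ccc(-c2cncc(/C=C/c3ccc(C(=O)NO)cc3)c2)cc1`: in this assay compound 3 also reaches only a limit, > 10000 nM.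

Compounds 1 and 2 share one core and differ in a single place: trifluoromethyl in place of methyl on an aromatic carbon. This change gives an at least 5.2-fold higher number from compound 1 to compound 2 (0.71 log units; beyond the scatter), and the true size of that step stays hidden because of the limit of > 10000 nM in this assay, at which 2 of the 3 values shown sit. Compound 3 has the same atoms as compound 1 joined differently; how the two cores differ is not broken down here. Compound 4 `O=C(NO)c1ccc(/C=C/c2cncc(-c3ccc(C(F)(F)F)cc3)c2)cc1` stands to compound 3 as compound 2 stands to compound 1: trifluoromethyl in place of methyl on an aromatic carbon, the same change at a place described in the same words. For compound 4 the step is expected to be a step that the limit leaves unreadable from compound 3 to compound 4. That expectation rests on compound 3 standing at the limit > 10000 nM and on the direction of an at least 5.2-fold higher number from compound 1 to compound 2 (0.71 log units; beyond the scatter). Compound 4 is therefore estimated at 25000 nM, most likely reported again only as a limit.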

Compound 4, half-maximal inhibitory concentration: > 10000 nM
Compound 4: a limit, no number; the forecaster's own chance of this, stated with the estimate: 85%; the middle value lies beyond the limit too.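

The step from compound 3 to compound 4 cannot be read, because both compounds give a limit of the assay and not a number: the limit of > 10000 nM in this assay, at which 3 of the 4 values shown sit.

The compounds shown leave open the true values of compound 2, compound 3 and compound 4, and so whether trifluoromethyl in place of methyl has the same size of effect on both cores.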